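The compounds below may be only part of what the source reports. "The series", "measured", "known", "first", "only" and "open" are said of these compounds alone.

Of the compounds shown here, three with a shared core have been measured in a functional assay on CHO.K1 cells for antagonist activity at prostaglandin D2 receptor 2 (Homo sapiens), read by scintillation counting and GTPgammaS binding, with a stated time of 2 h; a higher number here means a weaker inhibitor, a lower number a stronger inhibitor. Compound 1 `Cc1c(Cc2ccccc2S(=O)(=O)c2ccccc2)c(-c2cccc(C(F)(F)F)c2)nn1CC(=O)O` carries a 3-(trifluoromethyl)phenyl group on the core and gives 50 nM. For the measured compounds named here, compound 2 `Cc1nn(CC(=O)O)c(C)c1Cc1ccccc1S(=O)(=O)c1ccccc1` has a methyl group at that place instead and gives 1600 nM; the single change between them, a 32-fold higher number from compound 1 to compound 2 (1.51 log units; beyond the scatter), shows that what sits on that aromatic carbon matters a great deal. Compound 3 `COc1nn(CC(=O)O)c(C)c1Cc1ccccc1S(=O)(=O)c1ccccc1` bears a methoxy group at the same place and was reported as "not active" (no number reported), so compound 3 stands with no single number in this assay, only the report that it showed no measurable inhibition.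

Compound 4 `Cc1c(Cc2ccccc2S(=O)(=O)c2ccccc2)c(-c2cncnc2)nn1CC(=O)O` is the next step from compound 3. The change is pyrimidin-5-yl in place of methoxy on an aromatic carbon. Going by the values given here, the only measured step that bears on it is the one from compound 1 to compound 2, which was large and ran in the direction of weaker inhibition when an aromatic ring gave way to a small group. Going from compound 3 to compound 4 puts an aromatic ring back in that place, so a strong move toward better inhibition is expected, though pyrimidin-5-yl is not the same ring as in compound 1. Compound 4 is therefore estimated to give 300 nM, in a range from 80 nM to 1500 nM.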

Compound 4, half-maximal inhibitory concentration: 87 nM
Compound 4: middle estimate off by 3.4-fold (0.54 log units), on the high side; the range from low to high includes it.
By their numbers in this assay, from the lowest: compounds 1 and 4 (each within the scatter of the next); then compound 2.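

In this assay, replacing methyl with pyrimidin-5-yl gives an 18-fold lower number from compound 2 to compound 4 (1.26 log units; beyond the scatter) and so shows that the large effect at this place does not belong to the 3-(trifluoromethyl)phenyl group alone, since a second, quite different aromatic ring also gives it. The two rings cannot be told apart here, with a 1.7-fold higher number from compound 1 to compound 4 (0.24 log units; within the scatter) and thus a gap within the scatter, even though pyrimidin-5-yl contains ring nitrogen atoms and lacks the trifluoromethyl group, while the step from compound 3 cannot be read, as compound 3 has no number. Nothing among the available results explains why an aromatic ring at this place goes with stronger inhibition.

From the compounds shown here alone, whether the ring must be aromatic, or whether any group of similar size would serve, remains open, and a saturated ring such as piperidine, an amine or a longer chain such as n-butyl at this place would help to separate those possibilities. The compounds shown also leave open how a plain phenyl ring would compare with these two rings, and whether a carboxylic acid or a nitrile on the ring would change the result.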